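Aryl swap on the sulfonyl of compound 3

The source may hold more compounds than are shown below. What is called first, only, known or untested is meant among the compounds shown, and "the series" means these compounds.

Compound 1 `COC(=O)c1ccc(C2SCC(=O)N2c2ccc(N3CCN(Cc4cccc([N+](=O)[O-])c4)CC3)cn2)c(OC)c1` gives 37400 nM in a functional assay on Jurkat cells (Homo sapiens) for antiproliferative activity, read by MTT assay and trypan blue exclusion, with a stated time of 72 h; on this read-out higher numbers stand for weaker inhibition and lower numbers for stronger inhibition. Compound 2 `COC(=O)c1ccc(C2SCC(=O)N2c2ccc(N3CCNCC3)cn2)c(OC)c1` gives 19300 nM in this assay, and the step of a 1.9-fold lower number from compound 1 to compound 2 (0.29 log units; within the scatter) stays within the scatter. Compound 3 `COC(=O)c1ccc(C2SCC(=O)N2c2ccc(N3CCN(S(=O)(=O)c4cc(Cl)ccc4Cl)CC3)cn2)c(OC)c1` reaches only a limit of the assay, > 100000 nM, in this assay. Compound 3 thus sits at the limit of > 100000 nM in this assay, at which 1 of the 3 values shown sits, the weakest position among the numbers shown, with an at least 2.6-fold higher number from compound 1 to compound 3 (0.42 log units; beyond the scatter) and an at least 5.1-fold higher number from compound 2 to compound 3 (0.71 log units; beyond the scatter) both beyond the scatter.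

Compound 4 `COC(=O)c1ccc(C2SCC(=O)N2c2ccc(N3CCN(S(=O)(=O)c4ccc([N+](=O)[O-])cc4)CC3)cn2)c(OC)c1` differs from compound 3 in one place: 4-nitrophenyl in place of 2,5-dichlorophenyl on a sulfonyl sulfur. For the measured compounds named here, no measured step exchanges one aryl for another on the sulfonyl sulfur. The two steps that touch the sulfonyl, an at least 2.6-fold higher number from compound 1 to compound 3 (0.42 log units; beyond the scatter) and an at least 5.1-fold higher number from compound 2 to compound 3 (0.71 log units; beyond the scatter), show only that the (2,5-dichlorophenyl)sulfonyl carried the number to the limit. Compound 3 offers no number to move from, so the step to compound 4 in this assay cannot be set against a measured value. For compound 4 no shift beyond the scatter is expected, and the step is estimated as a step that the limit leaves unreadable from compound 3 to compound 4. Compound 4 is therefore expected at 120000 nM, with a range from 40000 nM to 400000 nM, and with a fair chance that the assay again reports only a limit.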

Compound 4, half-maximal inhibitory concentration: 54000 nM
Beside the measured number, compound 4's estimate is 2.2-fold (0.35 log units) above it, within the range that was stated.
By their numbers in this assay, from the lowest: compounds 2, 1 and 4 (each within the scatter of the next, the first and the last beyond it). At a limit, above all of these: compound 3.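

A sulfonyl on the ring amine nitrogen does not by itself carry the number to a limit: in this assay the aryl swap reads as an at least 1.8-fold lower number from compound 3 to compound 4 (0.26 log units; that floor lies within the scatter), so the true size of this change remains unfixed and only its floor is known. Measured against the free amine, the (4-nitrophenyl)sulfonyl gives a 2.8-fold higher number from compound 2 to compound 4 (0.45 log units; beyond the scatter), while against the 3-nitrobenzyl it gives a 1.4-fold higher number from compound 1 to compound 4 (0.16 log units; within the scatter), which leaves this sulfonamide and the benzyl compound level on this read-out and gives the series its first sulfonamide with a number. Compound 3 remains a limit of the assay and not a number: the limit of > 100000 nM in this assay, at which 1 of the 4 values shown sits.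

With only two aryls on the sulfonyl sulfur, and with these differing in both the two chlorines and the nitro group, the compounds shown do not separate what each substituent contributes, and a plain phenyl on the sulfonyl would be the direct reference point. Also open, from the compounds shown here alone, is whether a different group on the ring amine nitrogen, such as an acetyl or a short carboxylic acid chain, gives a lower number than compound 2 at 19300 nM.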